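The source may hold more compounds than are shown below. What is called first, only, known or untested is meant among the compounds shown, and "the series" means these compounds.

In a functional assay on cells (Neutrophil, Homo sapiens) for inhibition, with a stated time of 10 min (on this read-out higher numbers stand for weaker inhibition and lower numbers for stronger inhibition), compound 1 (`CCCC(O)Cn1ncc(C(=O)OCC)c1NC(=O)NC(C)C`) gives 1 nM and compound 2 (`CCOC(=O)c1cnn(CC(O)CC)c1NC(=O)Nc1ccc(F)cc1`) gives 1.9 nM. These two numbers lie within the usual scatter of each other, so on this evidence compound 2 cannot be told apart from compound 1. Compound 3 (`CCOC(=O)c1cnn(CC(O)CC)c1NC(=O)NC(C)C`) is compound 2 with one change, isopropyl in place of 4-fluorophenyl on an amide-type nitrogen. Among the compounds with values here, no measured pair shows this change on its own. Even so, compound 1 also carries isopropyl on an amide-type nitrogen and gives 1 nM, so a low number is plausible with that group. In this assay, the step of a 1.3-fold lower number from compound 2 to compound 3 (0.10 log units; within the scatter) is therefore expected to stay within the scatter. The estimated value for compound 3 is 1.5 nM, with an expected range of 0.5 nM to 5 nM.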

Compound 3, half-maximal inhibitory concentration: 0.0042 nM
Compound 3: middle estimate off by 360-fold (2.55 log units), on the high side; the measured number lies below the stated range.
By their numbers in this assay, from the lowest: compound 3; then compounds 1 and 2 (each within the scatter of the next).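

In this assay the group on the amide-type nitrogen proves decisive: isopropyl in place of 4-fluorophenyl gives a 450-fold lower number from compound 2 to compound 3 (2.66 log units; beyond the scatter), a drop that compound 1 and compound 2 could not reveal, as they differ in two places. The chain carrying the hydroxyl also matters, since hydrogen in place of methyl on a saturated chain carbon, three bonds along the chain from an oxygen on a saturated carbon, gives a 240-fold lower number from compound 1 to compound 3 (2.38 log units; beyond the scatter), with isopropyl unchanged. Each of these two single changes therefore moves the number strongly on its own.

Nothing available explains why either change has so large an effect. Going by these compounds, it also remains open whether a cyclopropyl or a plain phenyl on that nitrogen, or a hydrogen in place of the ethyl ester, would keep so low a number.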